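A few compounds are considered here, and "the series" means these few. Any claim that something is new, unique, unknown or untested is made for them only; others in the source may bear on it.

Compounds measured so far:
- compound 1, `COc1cc(/C=N/Nc2nc3ccccc3s2)ccc1O` — > 16700 nM
- compound 2, `Cc1ccc(/C=N/Nc2nc3ccccc3s2)c(C)c1` — > 17700 nM
- compound 3, `COc1ccc(/C=N/Nc2nc3ccccc3s2)c(OC)c1` — > 15900 nM

All three were tested in a functional assay on HCT-8 cells (Homo sapiens) for cytotoxicity, read by MTT assay, with a stated time of 72 h; a lower number here means a stronger inhibitor, a higher number a weaker inhibitor. Compound 1 gives > 16700 nM, and this is a limit of the assay rather than a number. Compound 2 gives > 17700 nM, again a limit. Compound 3 gives > 15900 nM, also a limit. So compound 1 stands where the other two stand: at the edge of what this assay can report, with no measurable inhibition at the highest concentration tested, as the limit of > 16700 nM in this assay, at which 1 of the 3 values shown sits, records for it.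

The next compound, compound 4 `Oc1ccc(/C=N/Nc2nc3ccccc3s2)cc1`, differs from compound 1 in one place: hydrogen in place of methoxy on an aromatic carbon, ortho to a hydroxy group and meta to a large group. Among the compounds with values here, no measured pair here shows what such a change does in this assay. With all three measured values sitting at limits, no step beyond the scatter is expected in either direction.

Compound 4 is therefore expected to give about 20000 nM in this assay, within 8000 nM to 60000 nM, most likely again reported as a limit. The estimated change from compound 1 is a step that the limit leaves unreadable from compound 1 to compound 4.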

Compound 4, half-maximal inhibitory concentration: > 18500 nM
Compound 4 gave a limit, no number (the forecaster's own chance of this, stated with the estimate: 85%); the middle value does not contradict the limit.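

Compound 1 and compound 4 are both reported only as limits in this assay, not as numbers, and the step between them cannot be read. The compounds shown leave open what hydrogen in place of methoxy actually does in this cell test, and whether any change on the shared core gives a measurable value.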